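The source may hold more compounds than are shown below. What is called first, only, known or untested is meant among the compounds shown, and "the series" means these compounds.

Notes on compound 2 (`O=C(NCc1cc(Cl)ccc1-n1cnnn1)[C@@H]1C[C@@H]2C[C@@H]2N1C(=O)[C@H](O)C1CCCCC1`): in an ADME assay on Caco-2 cells (Homo sapiens) for permeability, read by LC-MS, in the apical to basolateral direction, with a stated time of 60 min, at pH 6.5 (a higher number here means that the compound crosses the layer faster, a lower number that the compound crosses the layer more slowly), compound 2 gives 16 10^-6 cm/s. Compound 1 (`Cc1cccc([C@@H](O)C(=O)N2N=CC[C@H]2C(=O)NCc2cc(Cl)ccc2-n2cnnn2)c1`) gives 9.7 10^-6 cm/s, within the scatter of compound 2. Compound 3 (`COC(C)(C)[C@@H](O)C(=O)N1N=CC[C@H]1C(=O)NCc1cc(Cl)ccc1-n1cnnn1`) gives 1.7 10^-6 cm/s, a number beyond the scatter from that of compound 2.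

The next structure is compound 4 (`O=C(NCc1cc(Cl)ccc1-n1cnnn1)[C@@H]1C[C@@H]2C[C@@H]2N1C(=O)[C@H](O)c1ccccc1`), which differs from compound 2 as follows: phenyl in place of cyclohexyl on a saturated chain carbon bound to a carbonyl carbon and an oxygen on a saturated carbon. In words, this is phenyl in place of cyclohexyl on a saturated chain carbon bound to a carbonyl carbon and an oxygen on a saturated carbon.

Among the measured compounds shown here, no measured step makes this exchange. For the measured compounds named here, the only measured step at that place is a 5.7-fold lower number from compound 1 to compound 3 (0.76 log units; beyond the scatter), a modest step beyond the scatter. It replaces 3-methylphenyl with 1-methoxy-1-methylethyl on a core different from that of compound 2, so it shows that the number can shift with the group at this place, but gives no direct size for the present exchange. The nearest guide is compound 1, which carries an aromatic ring at that place and gives 9.7 10^-6 cm/s, though on a different core.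

A small fall in this assay is therefore expected, no larger than the scatter: the estimate is a 1.5-fold lower number from compound 2 to compound 4 (0.16 log units; within the scatter). For compound 4 the expected value is 11 10^-6 cm/s, with an estimated range of 5 10^-6 cm/s to 24 10^-6 cm/s.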

Compound 4, apparent permeability: 8 10^-6 cm/s
Compound 4: middle estimate off by 1.4-fold (0.14 log units), on the high side, within the range that was stated.
By their numbers in this assay, from the lowest: compound 3; then compounds 4, 1 and 2 (each within the scatter of the next).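

In this assay, the exchange of phenyl in place of cyclohexyl on a saturated chain carbon bound to a carbonyl carbon and an oxygen on a saturated carbon can now be read directly on one core, as a 2.0-fold lower number from compound 2 to compound 4 (0.30 log units; within the scatter). Among the compounds shown here, at this place on the core of compound 2, a six-membered aromatic ring of carbon only and a six-membered non-aromatic ring of carbon only are therefore not told apart by this read-out, whereas the only earlier step at this place, a 5.7-fold lower number from compound 1 to compound 3 (0.76 log units; beyond the scatter), with 1-methoxy-1-methylethyl in place of 3-methylphenyl on the core of compound 1, lies beyond the scatter. No measurement shown here bears on what lies behind the size of the new step.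

Still open, on these data alone, is whether 1-methoxy-1-methylethyl on the core of compound 2 would give a step of the size seen on the core of compound 1, and whether cyclohexyl and phenyl would again stay within the scatter of each other on that other core. Also open, as far as these compounds go, is how an amine, a carboxylic acid or a longer chain at this place would read in this assay.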